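Swapping the Ethoxy End of Compound 1 for a Pyridine Arm

This account rests on a few compounds, and the source may have more. Where it says the series, first, only, none or still open, it means among the compounds named here.

Measured so far:
compound 1 `CCOC(=O)CC(=O)N1CCSC1COc1ccccc1OC` – 21 mg/kg
compound 2 `COc1ccccc1OCC1SCCN1C(=O)C[S+](C)[O-]` – 25 mg/kg
compound 3 `C=CC(=O)N1CCSC1COc1ccccc1OC` – 74 mg/kg

All three share one core and differ only in the group hanging off the carbonyl carbon. In a functional assay on the whole organism for inhibition, with Cavia porcellus as the target (on this read-out higher numbers stand for an effect only at larger amounts of compound and lower numbers for an effect already at smaller amounts), compound 1 stands at the lowest of the three numbers; the step of a 1.2-fold higher number from compound 1 to compound 2 (0.08 log units; within the scatter) is within the scatter, while the step of a 3.5-fold higher number from compound 1 to compound 3 (0.55 log units; beyond the scatter) is a modest rise.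

Compound 4 `COc1ccccc1OCC1SCCN1C(=O)CC(=O)NCc1cccnc1` carries ((pyridin-3-yl)methyl)amino in place of ethoxy on a carbonyl carbon. Going by the values given here, no measured step exchanges ethoxy for anything, so the evidence is indirect. The step of a 1.2-fold higher number from compound 1 to compound 2 (0.08 log units; within the scatter) shows that altering the far end of this chain left the number essentially unchanged, whereas a 3.5-fold higher number from compound 1 to compound 3 (0.55 log units; beyond the scatter) shows that cutting the chain short raised it. Because a 1.2-fold higher number from compound 1 to compound 2 (0.08 log units; within the scatter) shows that changing only the far end of this chain stays within the scatter, and compound 4 likewise keeps the chain and changes only its end, I expect a 1.2-fold higher number from compound 1 to compound 4 (0.08 log units; within the scatter), a step not beyond the scatter. The estimate for compound 4 is 25 mg/kg, with a range from 10 mg/kg to 60 mg/kg.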

Compound 4, dose for half-maximal effect: 57 mg/kg
Estimate against measurement, compound 4: 2.3-fold (0.36 log units) below, within the range that was stated.
By their numbers in this assay, from the lowest: compounds 1 and 2 (each within the scatter of the next); then compounds 4 and 3 (each within the scatter of the next).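

Replacing ethoxy with ((pyridin-3-yl)methyl)amino on a carbonyl carbon gives a 2.7-fold higher number from compound 1 to compound 4 (0.43 log units; beyond the scatter) in this assay, so a larger dose is needed. Going by these compounds alone, this is the first measured change of the ethoxy group itself, and it shows that keeping the chain does not guarantee a number close to that of compound 1. No available evidence explains the shift.

On these data alone, it remains open whether the ring or the amide hydrogen matters more. Benzylamino would retain a ring without the ring nitrogen, while methylamino would retain the amide hydrogen without any ring.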